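Adding Chloro to the Urea Aryl Ring of Compound 3

The compounds below may be only part of what the source reports. "The series", "measured", "known", "first", "only" and "open" are said of these compounds alone.

Compound 1 `O=C(Nc1cccc(-n2cc(-c3ccncc3)c(-c3ccc(Cl)c(O)c3)n2)c1)Nc1cccc(C(F)(F)F)c1`: 3180 nM
Compound 2 `COc1cc(-c2nn(-c3cccc(NC(=O)Nc4ccc(Cl)c(Cl)c4)c3)cc2-c2ccncc2)ccc1Cl`: 1290 nM
Compound 3 `COc1cc(-c2nn(-c3cccc(NC(=O)Nc4cccc(C(F)(F)F)c4)c3)cc2-c2ccncc2)ccc1Cl`: 1100 nM

In a functional assay on OVCAR-4 cells (Homo sapiens) for inhibition, read by sulforhodamine B assay, with a stated time of 48 h (a lower number here means a stronger inhibitor of growth, a higher number a weaker inhibitor of growth), compound 3 gives 1100 nM, the lowest of the three numbers. Compound 2 comes next, with the gap from compound 2 to compound 3 standing at a 1.2-fold lower number from compound 2 to compound 3 (0.07 log units; within the scatter), which lies within the scatter, so the two cannot be ranked. Compound 1 sits furthest away, the gap from compound 1 to compound 3 being a 2.9-fold lower number from compound 1 to compound 3 (0.46 log units; beyond the scatter), a modest but real difference. That step is the methyl in place of hydrogen on an oxygen on an aromatic ring, not a change of the urea aryl ring.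

Compound 4 `COc1cc(-c2nn(-c3cccc(NC(=O)Nc4ccc(Cl)c(C(F)(F)F)c4)c3)cc2-c2ccncc2)ccc1Cl` differs from compound 3 by one change: chloro in place of hydrogen on an aromatic carbon. The step that speaks to this position is the exchange of the urea aryl ring between compound 2 and compound 3, which gave a 1.2-fold lower number from compound 2 to compound 3 (0.07 log units; within the scatter) and stayed within the scatter. The methyl step from compound 1 to compound 3 touches a different part of the molecule and adds nothing here. Among the measured compounds shown here, with only one relevant comparison, and that one flat, the expected change in this assay from compound 3 to compound 4 is a 1.2-fold lower number from compound 3 to compound 4 (0.06 log units; within the scatter), that is, none beyond the scatter. Compound 4 is therefore estimated at 950 nM, with a range from 450 nM to 2000 nM.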

Compound 4, concentration for 50% growth inhibition: 1290 nM
Compound 4: the middle estimate sits 1.4-fold (0.13 log units) below what was measured, and the stated range covers the measured number.
By their numbers in this assay, from the lowest: compounds 3, 2 and 4 (each within the scatter of the next); then compound 1.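

With chloro on the aromatic carbon ortho to a trifluoromethyl group and para to a large group, this assay gives a 1.2-fold higher number from compound 3 to compound 4 (0.07 log units; within the scatter), so at this carbon chloro and hydrogen cannot be told apart in this read-out. The other new step, trifluoromethyl in place of chloro on an aromatic carbon, gives no change at the digits printed from compound 2 to compound 4 (within the scatter), and so the 4-chloro-3-(trifluoromethyl)phenyl, 3,4-dichlorophenyl and 3-(trifluoromethyl)phenyl rings on the urea all read alike within the scatter, a pattern that rests on compounds 2, 3 and 4 alone. No measurement is at hand that would account for this flat reading.

The compounds shown leave open whether this aromatic carbon stays as flat with a group of another kind, such as an amine, a carboxylic acid or a longer chain like an ethoxy group, in place of chloro. They also leave open whether the 4-chloro-3-(trifluoromethyl)phenyl ring would read the same on the core of compound 1, which carries a hydroxyl where the others carry methoxy.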